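Methoxy removal from the pendant aryl ring, two cases

The source may hold more compounds than are shown below. What is called first, only, known or untested is meant among the compounds shown, and "the series" means these compounds.

Three compounds are measured in a functional assay on U-87MG ATCC cells for antiproliferative activity against U-87 MG (Homo sapiens), read by MTT assay, with a stated time of 48 h, tested at 50 uM; a lower number here means a stronger effect, a higher number a weaker effect of the compound at the concentration tested. Compound 1 `COc1ccc(-c2nc(C)c(C(=O)CSc3nc(N)c(C#N)c(-c4ccc(Cl)cc4)n3)s2)cc1` gives 23.1%. Compound 3 `COc1ccc(-c2nc(C)c(C(=O)CSc3nc(-c4ccc(OC)c(OC)c4)c(C#N)c(=O)[nH]3)s2)cc1` gives 22.2%, a value within the scatter of that of compound 1. Compound 2 `COc1ccc(-c2nc(C)c(C(=O)CSc3nc(-c4cccc(OC)c4)c(C#N)c(=O)[nH]3)s2)cc1` gives 43.2%. The difference between the core of compound 1 and that of compound 3 is not broken down here. Between compound 3 and compound 2 the change is hydrogen in place of methoxy on an aromatic carbon, and it gives a number 21 percentage points higher from compound 3 to compound 2 (beyond the scatter).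

Compound 4 `Cc1nc(-c2ccccc2)sc1C(=O)CSc1nc(N)c(C#N)c(-c2ccc(Cl)cc2)n1` is not yet measured. It differs from compound 1 by hydrogen in place of methoxy on an aromatic carbon, the same kind of change as from compound 3 to compound 2, but not the same: in the measured pair the methoxy that leaves sits ortho to a methoxy group, whereas in compound 4 the position carries no such neighbour, only para to a large group. On that one step, the expectation for compound 4 in this assay is a number 13.9 percentage points higher from compound 1 to compound 4 (beyond the scatter), giving an estimated 37% with a range from 20% to 58%. This expected step is set weaker than the measured one because the measured step of a number 21 percentage points higher from compound 3 to compound 2 (beyond the scatter) comes from a position ortho to a methoxy group, a neighbour that compound 4 does not have.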

Compound 4, a percentage reported as activity, at one concentration (the size of the read-out at that concentration, not a potency): 44.3%
Compound 4: the middle estimate sits 7.3 percentage points below what was measured, within the range that was stated.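

In this assay, the change from 4-methoxyphenyl to phenyl gives a number 21.2 percentage points higher from compound 1 to compound 4 (beyond the scatter), so losing this methoxy weakens the effect on the core of compound 1 as well. Set beside the earlier step, the size of the change carries over between the two cores: the same change on two cores in this assay, a number 21 percentage points higher (beyond the scatter) from compound 3 to compound 2 and a number 21.2 percentage points higher (beyond the scatter) from compound 1 to compound 4, 0.2 percentage points apart, within the scatter of two such steps. This rests on two pairs only, which differ both in the core and in the aryl ring that loses its methoxy, and each value is a read-out at one concentration, so it shows neither a general rule for the series nor any change in potency.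

As far as these compounds go, whether a hydroxy group, a fluorine atom or a longer chain such as ethoxy on that phenyl ring would keep the effect seen with methoxy remains open. Also open, from the compounds shown here alone, is whether an amine at the same carbon would follow the methoxy or the hydrogen compounds, and how the step would run on a third core.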